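The source may hold more compounds than are shown below. What is called first, only, known or untested is meant among the compounds shown, and "the series" means these compounds.

Compound 1, `CCO/N=C(/c1ccc(Br)cc1)C1CCN(C(C)CCNC(=O)c2c(Cl)cncc2Cl)CC1`: 33800 nM. Compound 2, `CC(CCNC(=O)c1c(Cl)cncc1Cl)N1CCC(C(Oc2ccc(C(F)(F)F)cc2)c2ccc(C(F)(F)F)cc2)CC1`: 3100 nM. Compound 3, `CC(CCNC(=O)c1c(Cl)cncc1Cl)N1CCC(C(Oc2ccccn2)c2ccc(Br)cc2)CC1`: 33700 nM.

These three have been measured in an ADME assay on PBMC cells (Homo sapiens) for cytotoxicity; a higher number here means that more compound is tolerated, a lower number that less compound is tolerated. Among them compound 2 stands lowest, with compound 1 and compound 3 both sitting above it by a gap beyond the scatter. Compound 4, `CC(CCNC(=O)c1c(Cl)cncc1Cl)N1CCC(C(Oc2cccc(C(=O)O)n2)c2ccc(C(F)(F)F)cc2)CC1`, has not yet been measured in this assay. It differs from compound 2 in one place: 6-carboxypyridin-2-yl in place of 4-(trifluoromethyl)phenyl on an oxygen on a saturated carbon. Within the data shown here, no step between measured compounds touches this position, so the size of the effect has to be guessed. Since compound 2 gives 3100 nM while compound 3 gives 33700 nM and compound 1 gives 33800 nM, an upward move seems the more likely direction. Compound 4 is therefore expected to come out near 20000 nM, within a range from 6000 nM to 70000 nM, which corresponds to an expected step of a 6.5-fold higher number from compound 2 to compound 4 (0.81 log units; beyond the scatter).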

Compound 4, half-maximal cytotoxic concentration: 28700 nM
Compound 4: middle estimate off by 1.4-fold (0.16 log units), on the low side, and the stated range covers the measured number.
By their numbers in this assay, from the lowest: compound 2; then compounds 4, 3 and 1 (each within the scatter of the next).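

In this assay, exchanging the 4-(trifluoromethyl)phenyl group for a 6-carboxypyridin-2-yl group gives a 9.3-fold higher number from compound 2 to compound 4 (0.97 log units; beyond the scatter). Among these compounds, this is the first step read at this position, and it shows that the group there alone can move the number beyond the scatter. No evidence is available to explain the change. This single step cannot separate the ring nitrogen from the carboxylic acid, nor either of them from the loss of trifluoromethyl. As far as these compounds go, a methyl ester or primary amide in place of the carboxylic acid, or a phenyl ring carrying the acid, remains open.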